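The source may report more compounds than this note shows. Statements on the series, on what has been measured and on what is new or still open speak of the compounds shown alone.

In an assay on L cells for inhibition of Protein-serine O-palmitoleoyltransferase porcupine (Mus musculus), read by reporter gene assay, with a stated time of 24 h (a lower number here means that less compound is needed, a higher number that more compound is needed for the effect), compound 1 `O=C(CSc1nc2c(c(=O)n1-c1ccccc1)SCC2)Nc1ccc(N2CCCCC2)cc1` gives 30 nM. Among the measured compounds shown here, the only other measured compound, compound 2 `COc1ccc(-n2nc(C(=O)NCC(=O)Nc3nc4ccc(Cl)cc4s3)c3ccccc3c2=O)cc1`, gives 15 nM in this assay, and the two numbers lie within the usual scatter of each other, so nothing separates the pair. For the measured compounds named here, compound 2 and compound 1 share no common frame from which a single change could be traced, so no measured step exists in this set. Compound 3 `O=C(CSc1nc2c(c(=O)n1-c1ccccc1)SCC2)Nc1ccc(-c2ccccn2)cc1` differs from compound 1 in one place: pyridin-2-yl in place of piperidin-1-yl on an aromatic carbon. Without any measured step of this kind to lean on, the size of the effect is open; the expectation is a step of roughly the usual scatter toward a somewhat higher number, the expected step being a 2.0-fold higher number from compound 1 to compound 3 (0.30 log units; within the scatter). Compound 3 is therefore estimated at 60 nM, with a range from 15 nM to 250 nM.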

Compound 3, half-maximal effective concentration: 4 nM
Estimate against measurement, compound 3: 15-fold (1.18 log units) above; the whole stated range lies above it.
By their numbers in this assay, from the lowest: compound 3; then compounds 2 and 1 (each within the scatter of the next).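

In this assay, among the compounds shown here, this is the first single change that can be read in the set, and replacing piperidin-1-yl with pyridin-2-yl on an aromatic carbon, para to a large group, gives a 7.5-fold lower number from compound 1 to compound 3 (0.88 log units; beyond the scatter), a step beyond the scatter. The position thus responds to the identity of the group: the two groups match in heavy atoms, hydrogen-bond donors, hydrogen-bond acceptors and net charge, yet one ring is non-aromatic and the other aromatic. Nothing available explains the size of this step.

The compounds shown leave open whether the lower number goes with the aromatic ring itself or with its nitrogen, a question that phenyl, pyridin-3-yl or pyridin-4-yl at the same place would address. Going by these compounds, how morpholin-4-yl or a small group such as methoxy would read there also remains unknown.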